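This account rests on a few compounds, and the source may have more. Where it says the series, first, only, none or still open, it means among the compounds named here.

Measured in an ADME assay (liver) for pharmacokinetics, with Liver microsome (Homo sapiens) as the target, using microsomes; a lower number here means that the compound disappears faster, a higher number that the compound lasts longer:
compound 1 `CCOc1cc(NC(=O)C2(NC(=O)c3ccc4c(C5CCCC5)c(-c5ncc(Cl)cn5)n(C)c4c3)CCC2)ccc1/C=C/C(=O)OC(=O)C[C@H](O)C(=O)O`: 5.57 h
compound 2 `CCOc1cc(NC(=O)C2(NC(=O)c3ccc4c(C5CCCC5)c(-c5ncc(Cl)cn5)n(C)c4c3)CCC2)ccc1/C=C/C(=O)OCOP(=O)(O)O`: 0.167 h
compound 3 `CCOC(=O)/C=C/c1ccc(NC(=O)C2(NC(=O)c3ccc4c(C5CCCC5)c(-c5ncc(Cl)cn5)n(C)c4c3)CCC2)cc1OCC`: > 5 h (a limit of the assay)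

Compound 2 holds the lowest number shown in this assay. The gap to the nearest number is a 33-fold lower number from compound 1 to compound 2 (1.52 log units; beyond the scatter).

Compound 4 `CCCOC(=O)/C=C/c1ccc(NC(=O)C2(NC(=O)c3ccc4c(C5CCCC5)c(-c5ncc(Cl)cn5)n(C)c4c3)CCC2)cc1OCC` departs from compound 2 by a group of 2 heavy atoms (2 carbon; no ring) in place of a group of 5 heavy atoms (4 oxygen, 1 phosphorus; no ring), on a saturated chain carbon bound to an oxygen next to a carbonyl group. Ethyl enters on a saturated chain carbon bound to an oxygen next to a carbonyl group.

The measured step closest to this change is an at least 29-fold higher number from compound 2 to compound 3 (1.47 log units; beyond the scatter), which leaves the same group and ends on a limit. On that measured step, a large upward move is expected, the estimated 36-fold higher number from compound 2 to compound 4 (1.56 log units; beyond the scatter). For compound 4 the estimate is 6 h, with an expected range of 3 h to 15 h.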

Compound 4, half-life: > 5 h
Compound 4: a limit, no number; the forecaster's own chance of this, stated with the estimate: 60%; the middle value lies beyond the limit too.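

In this assay, ethyl in place of the phosphorus-bearing group, on a saturated chain carbon bound to an oxygen next to a carbonyl group, gives an at least 29-fold higher number from compound 2 to compound 4 (1.47 log units; beyond the scatter). Compound 4 gives > 5 h, which is a limit of the assay. The large rise seen with compound 3 thus recurs with a second group at this place, and both values now sit at the same limit: the limit of > 5 h in this assay, at which 2 of the 4 values shown sit.

On these data alone, the steps from compound 1 and compound 3 to compound 4 cannot be read, so their order stays open. Also open, as far as these compounds go, is how a longer chain or an amine at this place would read in this assay.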